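A few compounds are considered here, and "the series" means these few. Any claim that something is new, unique, unknown or untested is made for them only; others in the source may bear on it.

In a functional assay on cells (Neutrophil, Homo sapiens) for inhibition, with a stated time of 10 min (a higher number here means a weaker inhibitor, a lower number a stronger inhibitor), compound 2 `CCOC(=O)c1cnn2c1N(C(=O)Nc1ccccc1F)C(c1ccccc1)C2` gives 7.5 nM, the lowest number in this small set. Compound 1 `O=C(Nc1ccccc1F)N1c2ccnn2CC1c1ccccc1`, which carries hydrogen in place of ethoxycarbonyl, reaches only a limit of the assay, > 1000 nM. Restoring the ester therefore gives an at least 130-fold lower number from compound 1 to compound 2 (2.12 log units; beyond the scatter). Compound 3 `CCOC(=O)c1cnn2c1N(C(=O)Nc1cccc3ccccc13)C(c1ccccc1)C2`, with naphthalen-1-yl in place of 2-fluorophenyl on the amide-type nitrogen, gives 206 nM, which is a 27-fold higher number from compound 2 to compound 3 (1.44 log units; beyond the scatter).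

Compound 4 `NC(=O)c1cnn2c1N(C(=O)Nc1ccccc1F)C(c1ccccc1)C2` keeps the rest of compound 2 but has amino in place of ethoxy on a carbonyl carbon. Within the data shown here, no measured step makes this exact exchange. The nearest is an at least 130-fold lower number from compound 1 to compound 2 (2.12 log units; beyond the scatter), which bears on the same group but concerns all of it, whereas compound 4 retains the carbonyl. The step of a 27-fold higher number from compound 2 to compound 3 (1.44 log units; beyond the scatter) lies elsewhere in the molecule and shows only how far one change can move the number in this assay. A step toward a higher number is therefore expected, beyond the scatter but smaller than the loss of the whole ester. The expected step is an 8.0-fold higher number from compound 2 to compound 4 (0.90 log units; beyond the scatter). For compound 4 the estimated value is 60 nM, within an expected range of 8 nM to 600 nM.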

Compound 4, half-maximal inhibitory concentration: 6.2 nM
For compound 4 the middle estimate is 9.7-fold (0.99 log units) above the measured one; measured number below the stated range.
By their numbers in this assay, from the lowest: compounds 4 and 2 (each within the scatter of the next); then compound 3. At a limit, above all of these: compound 1.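

In this assay, amino can take the place of ethoxy on the carbonyl carbon with no change beyond the scatter, a 1.2-fold lower number from compound 2 to compound 4 (0.08 log units; within the scatter), even though three heavy atoms give way to one and a hydrogen-bond donor enters. Carbamoyl in place of hydrogen on the aromatic carbon gives an at least 160-fold lower number from compound 1 to compound 4 (2.20 log units; beyond the scatter), so the large step first seen with ethoxycarbonyl does not depend on the ethoxy part. Compound 1 stands at a limit, so this step has only a bound for its size: the limit of > 1000 nM in this assay, at which 1 of the 4 values shown sits.

The compounds shown do not tell whether a carbonyl is required at this carbon, since a nitrile or a carboxylic acid there would be needed to test it. They also leave open whether a methyl amide would keep the number of compound 4.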